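The source may report more compounds than this note shows. Statements on the series, on what has been measured and on what is new or still open speak of the compounds shown alone.

Compound 1 `COc1cccc(CNc2ncnc3ccc(-c4cnn(C)c4)cc23)c1`: 36000 nM
Compound 2 `CC(Nc1nc(N)nc2ccc(-c3cnn(C4CCNCC4)c3)cc12)c1c(Cl)ccc(F)c1Cl`: 1580 nM
Compound 3 `CC(Oc1nc(N)nc2ccc(-c3cnn(C4CCNCC4)c3)cc12)c1c(Cl)ccc(F)c1Cl`: 7120 nM

All three values come from a functional assay on SK-BR-3 cells (Homo sapiens) for antiproliferative activity, read by MTT assay, with a stated time of 72 h; on this read-out lower numbers stand for stronger inhibition and higher numbers for weaker inhibition. Compound 3, at 7120 nM, stands in the middle of the set: compound 2 reads lower at 1580 nM and compound 1 reads higher at 36000 nM, each gap lying beyond the usual scatter.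

Compound 4 `CC(Oc1ncnc2ccc(-c3cnn(C4CCNCC4)c3)cc12)c1c(Cl)ccc(F)c1Cl` departs from compound 3 in one place, with hydrogen in place of amino on an aromatic carbon, between two ring nitrogen atoms (hydrogen in place of amino on an aromatic carbon). Going by the values given here, no measured pair isolates this change, so its size has no direct precedent. Compound 1 also carries hydrogen there and gives 36000 nM, but it differs from compound 3 elsewhere too, which makes it only a weak guide. A modest rise in the number in this assay is therefore expected, though a step within the scatter would be no surprise. The estimated change is a 1.4-fold higher number from compound 3 to compound 4 (0.15 log units; within the scatter). For compound 4 the expected value is 10000 nM, with an estimated range of 3500 nM to 30000 nM.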

Compound 4, half-maximal inhibitory concentration: 2500 nM
Estimate against measurement, compound 4: 4.0-fold (0.60 log units) above; measured number outside the range, below it.
By their numbers in this assay, from the lowest: compounds 2 and 4 (each within the scatter of the next); then compound 3; then compound 1.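

In this assay hydrogen in place of amino on an aromatic carbon, between two ring nitrogen atoms, gives a 2.8-fold lower number from compound 3 to compound 4 (0.45 log units; beyond the scatter) and so the amino group is not required at this position for the activity read here. Going by these compounds alone, this pair is the first direct reading of the position: compound 1 also carries hydrogen there but differs from compound 3 elsewhere too, so it could give no such reading. Nothing measured here offers a reason for the step.

Going by these compounds, whether the same change would move the number in the same direction on compound 2 stays open, as a single pair speaks to it. On these data alone, how a methyl group, a methoxy group or a dimethylamino group would read on this carbon also remains unknown.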